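Dropping the Chloro from Compound 3: Expected Vero Toxicity

The compounds below may be only part of what the source reports. "The series", "measured", "known", "first", "only" and "open" are said of these compounds alone.

Compound 1, `NC(=O)c1cccc2[nH]c(-c3ccccn3)nc12`: 224 uM
Compound 2, `O=C(NCCO)c1cccc2[nH]c(-c3ccncc3)nc12`: 498 uM
Compound 3, `COc1ccc(-c2nc3c(C(=O)Nc4cnc(Cl)cn4)cccc3[nH]2)cc1OC`: 78.3 uM

Of the compounds shown here, three built on a shared core have been measured in an ADME assay on Vero cells (Chlorocebus sabaeus) for cytotoxicity; on this read-out lower numbers stand for higher toxicity in this test and higher numbers for lower toxicity in this test. Compound 3, which carries the (5-chloropyrazin-2-yl)amino group, gives 78.3 uM and stands lowest of the three numbers, so it is the most toxic of the set in this assay. Its nearest neighbour is compound 1, whose number lies beyond the scatter above it, and compound 2 lies further still. Among the compounds with values here, no pair of the measured compounds differs in only one place, so no single-step comparison is available among them.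

Compound 4, `COc1ccc(-c2nc3c(C(=O)Nc4cnccn4)cccc3[nH]2)cc1OC`, has not yet been tested in this assay. It differs from compound 3 in one respect: hydrogen in place of chloro on an aromatic carbon. The change is small, a single chlorine atom exchanged for hydrogen on the six-membered aromatic ring with 2 nitrogen, while the rest of the molecule, including the core and the dimethoxyphenyl substituent, is unchanged.

Within the data shown here, with nothing among the measured compounds to anchor this exact step, the expectation is cautious: the step from compound 3 to compound 4 in this assay is estimated at a 1.4-fold higher number from compound 3 to compound 4 (0.15 log units; within the scatter), a shift toward a higher number that may not exceed the scatter. Compound 4 is therefore expected to give about 110 uM, within a range of 50 uM to 250 uM.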

Compound 4, half-maximal toxic concentration: 98.8 uM
For compound 4 the middle estimate is 1.1-fold (0.05 log units) above the measured one; low and high end bracket the measured number.
By their numbers in this assay, from the lowest: compounds 3 and 4 (each within the scatter of the next); then compound 1; then compound 2.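

In this assay, within the data shown here, the exchange of chloro for hydrogen on an aromatic carbon of the six-membered aromatic ring with 2 nitrogen, para to a large group, supplies the first comparison in this set that differs in one place only: a 1.3-fold higher number from compound 3 to compound 4 (0.10 log units; within the scatter). On this read-out, the 5-chloropyrazin-2-yl and pyrazin-2-yl forms therefore cannot be told apart, and this single atom at this position makes no difference that exceeds the scatter between repeated measurements. Nothing available here bears on why the step is this small.

A single exchange does not show whether the position would stay as unresponsive with a larger or differently built group in place of the chloro, such as an amine, a methoxy group or a carboxylic acid. Among these compounds, it also leaves open whether hydrogen and chloro would remain indistinguishable without the dimethoxyphenyl group, and no single-place step separates the contribution of that group or of the amide substituent to the higher numbers of compound 1 and compound 2.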